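This account rests on a few compounds, and the source may have more. Where it says the series, first, only, none or still open, it means among the compounds named here.

Of the compounds shown here, three sharing one core have been tested in a functional assay on MCF7 cells (Homo sapiens) for inhibition, read by CCK-8 assay, with a stated time of 48 h (a higher number here means a weaker inhibitor, a lower number a stronger inhibitor), and all three sit at the upper limit of what the measurement can report. Compound 1 `COc1cc(-c2cc3nccc(-c4cc(OC)c(OC)c(OC)c4)n3n2)cc(OC)c1OC` carries a second trimethoxyphenyl group; in this assay compound 1 gives > 10000 nM, which is a limit rather than a number. Compound 2 `COc1cc(-c2cc3nccc(-c4c[nH]c5ccccc45)n3n2)cc(OC)c1OC` replaces that group with an indolyl ring; in this assay compound 2 gives > 10000 nM, again a limit. Compound 3 `COc1cc(-c2ccnc3cc(-c4cccc(C#N)c4)nn23)cc(OC)c1OC` carries a 3-cyanophenyl group; in this assay compound 3 gives > 10000 nM, also only a limit. So compound 3 stands where every other compound here stands, at the ceiling of the measurement (the limit of > 10000 nM in this assay, at which 3 of the 3 values shown sit), and no value sets it apart from compound 1 or compound 2.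

Compound 4 `COc1cc(-c2ccnc3cc(-c4ccc(C(C)=O)cc4)nn23)cc(OC)c1OC` has not yet been measured. It differs from compound 3 in one place (4-acetylphenyl in place of 3-cyanophenyl on an aromatic carbon). For the measured compounds named here, no step between measured compounds is available to guide a forecast, and nothing here links a change of this kind to a gain in inhibition. The step from compound 3 to compound 4 is therefore expected to be none beyond the scatter: a step that the limit leaves unreadable from compound 3 to compound 4. Compound 4 is expected to give about 12000 nM in this assay, most likely again reported only as a limit, with a range from 3000 nM to 40000 nM.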

Compound 4, half-maximal inhibitory concentration: 5230 nM
For compound 4 the middle estimate is 2.3-fold (0.36 log units) above the measured one; low and high end bracket the measured number.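

In this assay compound 4 gives 5230 nM, the first reading in this series that is an actual number rather than the ceiling of the measurement: the limit of > 10000 nM in this assay, at which 3 of the 4 values shown sit.

From the compounds shown here alone, putting 4-acetylphenyl in place of 3-cyanophenyl gives an at least 1.9-fold lower number from compound 3 to compound 4 (0.28 log units; that floor lies within the scatter), and the true size of the step stays unknown, as the reading for compound 3 is only a limit, so the change could be barely more than the scatter or much larger. The swap also alters two things at once, the group itself (a nitrile becomes an acetyl carbonyl) and its place on the phenyl ring, as the names 3-cyanophenyl and 4-acetylphenyl show, and this single pair cannot separate the two.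

Going by these compounds, it remains open whether the number in compound 4 follows the acetyl group or its place on the ring, a question that 3-acetylphenyl and 4-cyanophenyl at the same carbon would answer. Also open, on these data alone, is how other groups at that place on the phenyl ring would read, such as an amine or a carboxylic acid.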